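Working notes: compound 3 to compound 4

A few compounds are considered here, and "the series" means these few. Any claim that something is new, unique, unknown or untested is made for them only; others in the source may bear on it.

Among the compounds with values here, the series so far offers a single reading. In an ADME assay on Vero cells (Chlorocebus sabaeus) for cytotoxicity (on this read-out higher numbers stand for lower toxicity in this test and lower numbers for higher toxicity in this test), compound 1 (`CCCCCCCCCCCCOc1ncnc2c1ncn2CC(=O)OCC`) gives > 10 ug/mL, which is a limit and not a number. For compound 2 (`Clc1nc(OCc2ccc(Cl)c(Cl)c2)c2nc[nH]c2n1`) the entry is "not determined" (no result reported). For compound 3 (`CCCCCCCCCCSc1nc(N)nc2c1ncn2CC(=O)N[C@@H](CO)C(=O)OC`) the entry is "not determined" (no result reported), so compound 3 has no standing of its own on this read-out and offers no starting value.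

The next compound to be tested is compound 4 (`CCCCCCCCCCSc1nc(N)nc2c1ncn2CC`). The change is methyl in place of (2-hydroxy-1-(methoxycarbonyl)ethyl)carbamoyl on a saturated chain carbon bound to an aromatic nitrogen. Within the data shown here, although this removes most of the side chain, no pair of measured compounds shows what an exchange of this kind does in this assay.

Among the measured compounds shown here, no direction can therefore be assigned, and no step beyond the usual scatter is expected from the one reading available. That reading, compound 1 at > 10 ug/mL, is the sole basis for the expectation, and it differs from compound 4 in more than one place. A result reported only as a limit would be unsurprising. The estimated value for compound 4 is 15 ug/mL, with an expected range of 5 ug/mL to 50 ug/mL.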

Compound 4, half-maximal cytotoxic concentration: 12.3 ug/mL
For compound 4 the middle estimate is 1.2-fold (0.09 log units) above the measured one; low and high end bracket the measured number.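

No step can be read from compound 3 to compound 4: in this assay compound 3 has no reported result, so compound 4 at 12.3 ug/mL stands without a partner. Nothing shown bears on this value. Going by these compounds, what exchanging (2-hydroxy-1-(methoxycarbonyl)ethyl)carbamoyl for methyl does on this read-out remains open.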